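Swapping Carboxy for Dimethylaminomethyl on a Side Chain

This account rests on a few compounds, and the source may have more. Where it says the series, first, only, none or still open, it means among the compounds named here.

Of the compounds shown here, two have so far been tested in an assay on Cerebral cortex for binding affinity to adenosine receptor A1 (Cavia porcellus), read by radioligand binding; a higher number here means a weaker inhibitor, a lower number a stronger inhibitor. Compound 1 `CCCn1c(=O)n(CC(=O)O)c(=O)c2[nH]cnc21` gives > 200000 nM there, which is a limit of the assay rather than a number. Compound 2 `CCCn1c(=O)n(C)c(=O)c2c1ncn2CCC(=O)O` likewise reaches only > 200000 nM in this assay, again a limit and not a number. Going by the values given here, both results sit at the same boundary, (the limit of > 200000 nM in this assay, at which 2 of the 2 values shown sit), so no measured step between them can be written down, and nothing shows whether one compound binds more strongly than the other.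

Compound 3 `CCCn1c(=O)n(C)c(=O)c2c1ncn2CCCN(C)C` has not yet been measured. It differs from compound 2 in one place: (dimethylamino)methyl in place of carboxy on a saturated chain carbon, two bonds along the chain from an aromatic nitrogen. The acid group leaves and a chain carrying a nitrogen with two methyl groups arrives in its place.

Among the compounds with values here, the two measured values are limits only, so there is no step of known size to lean on. From the compounds shown here alone, the expectation for an at least 6.6-fold lower number from compound 2 to compound 3 (0.82 log units; beyond the scatter) is a move toward stronger binding, large enough to clear the usual scatter, though the starting point itself is unknown. Compound 3 is expected to give about 30000 nM in this assay, within a plausible range from 5000 nM to 200000 nM, with a real chance that the assay again reports only a limit.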

Compound 3, inhibition constant: > 200000 nM
Compound 3: only a limit was reported; the forecaster's own chance of this, stated with the estimate: 35%; middle value at least 6.6-fold (0.82 log units) away from the limit.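

Compound 2 and compound 3 both reach only a limit of the assay and not a number, so no step between them can be read: the limit of > 200000 nM in this assay, at which 3 of the 3 values shown sit.

The compounds shown leave open whether (dimethylamino)methyl in place of carboxy changes binding at all, and how far beyond this limit any of the three values lies.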